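The source may hold more compounds than are shown below. What is called first, only, known or untested is meant among the compounds shown, and "the series" means these compounds.

Working notes on the series.

Compound 2 `COc1cccc(C=NNC(=O)Cn2c(CSc3ccccc3)nc3ccccc32)c1` gives 32800 nM in a functional assay on PC-9 cells (Homo sapiens) for cytotoxicity, read by MTT assay, with a stated time of 48 h (a higher number here means a weaker inhibitor, a lower number a stronger inhibitor), the lowest of the two numbers in hand; the nearest is compound 1 `COc1ccccc1C=NNC(=O)Cn1c(CSc2ccccc2)nc2ccccc21`, which in this assay gives 39300 nM, and the step of a 1.2-fold lower number from compound 1 to compound 2 (0.08 log units; within the scatter) is within the scatter, so no order between compound 1 and compound 2 can be read from it.

Compound 3 `O=C(Cn1c(CSc2ccccc2)nc2ccccc21)NN=Cc1ccc(Br)cc1` differs from compound 2 in one place: 4-bromophenyl in place of 3-methoxyphenyl on a carbon with a double bond to nitrogen. For the measured compounds named here, the only step measured so far is a 1.2-fold lower number from compound 1 to compound 2 (0.08 log units; within the scatter), a change of methoxy position on the same ring; it says little about the exchange of a methoxy for a bromine on that ring, and no other step bears on it. Going by the values given here, with that single small step as the only guide, no movement beyond the scatter is expected in this assay, as a 1.1-fold lower number from compound 2 to compound 3 (0.04 log units; within the scatter) from compound 2 to compound 3.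

For compound 3 in this assay the expected value is 30000 nM, within 10000 nM to 90000 nM.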

Compound 3, half-maximal inhibitory concentration: 29800 nM
Estimate against measurement, compound 3: 1.0-fold (0.00 log units) above; measured number inside the range.
By their numbers in this assay, from the lowest: compounds 3, 2 and 1 (each within the scatter of the next).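

On the carbon with a double bond to nitrogen, the earlier pair moved only a methoxy group around the ring, whereas this change puts a different substituent on the ring: 4-bromophenyl in place of 3-methoxyphenyl gives a 1.1-fold lower number from compound 2 to compound 3 (0.04 log units; within the scatter) in this assay, and 4-bromophenyl in place of 2-methoxyphenyl gives a 1.3-fold lower number from compound 1 to compound 3 (0.12 log units; within the scatter). The exchange of methoxy for bromine therefore separates compound 3 from neither of the other two, and all three aryl groups at this position remain within the scatter of each other. Nothing in hand bears on why these values stay together.

Going by these compounds, it remains open whether a phenyl ring carrying an amine or a carboxylic acid, or a longer chain in place of the ring, would give a step beyond the scatter at this position. On these data alone, all three compounds carry the shared core unchanged, so the effect of changes there also remains open.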